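Compound 3: one hydroxy fewer than compound 2

The source may hold more compounds than are shown below. What is called first, only, known or untested is meant among the compounds shown, and "the series" means these compounds.

Two compounds of the series have numbers in a functional assay on BV-2 cells (Mus musculus) for inhibition, read by Griess assay, with a stated time of 24 h, in the presence of a further agent that is not named here; on this read-out higher numbers stand for weaker inhibition and lower numbers for stronger inhibition. Compound 1 `COc1ccc(-c2coc3c(O)c(O)ccc3c2=O)cc1O` gives 6870 nM in this assay. Compound 2 `COC1C(=O)c2c(O)cc(O)cc2OC1c1ccc(O)c(O)c1` gives 19300 nM in this assay, the higher of the two numbers and so the weaker inhibition; its gap to compound 1 lies beyond the scatter. Compound 3 `COC1C(=O)c2c(O)cc(O)cc2OC1c1ccc(O)cc1` is not yet measured in this assay. It differs from compound 2 in a single place: hydrogen in place of hydroxy on an aromatic carbon. Within the data shown here, no pair of measured compounds shows this change, so the series gives no direct reading of its effect. For compound 3 the change is expected to bring a modest step in this assay, if anything toward a higher number, and it may well stay within the scatter. Compound 3 is estimated at 26000 nM, with a range from 10000 nM to 65000 nM. The expected step is a 1.3-fold higher number from compound 2 to compound 3 (0.13 log units; within the scatter).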

Compound 3, half-maximal inhibitory concentration: 19500 nM
Compound 3: middle estimate off by 1.3-fold (0.12 log units), on the high side; the measured number falls inside the stated range.
By their numbers in this assay, from the lowest: compound 1; then compounds 2 and 3 (each within the scatter of the next).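

In this assay, among these compounds, the swap of hydroxy for hydrogen on an aromatic carbon, ortho to a hydroxy group, is read directly for the first time, and the step of a 1.0-fold higher number from compound 2 to compound 3 (0.00 log units; within the scatter) shows that this hydroxy can go without a measurable effect on the number. At this position, then, the loss of that hydroxy leaves the read-out within the scatter, so it gives no sign that this group matters for inhibition here. Nothing at hand explains this result.

Still open, from the compounds shown here alone, is whether an amine, a fluorine atom or a carboxylic acid on the same carbon would give a step beyond the scatter. Also open, going by these compounds, are the effect of removing the hydroxy group that stays on this ring and whether the same swap would read alike on the core of compound 1.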